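The compounds below may be only part of what the source reports. "The series", "measured", "known", "first", "only" and "open" are said of these compounds alone.

Three compounds sharing a common core were characterized in a physicochemical assay for acid dissociation. Compound 1 `COc1cccc(CNCCCNc2ccnc3cc(Cc4ccccc4)ccc23)c1O` gives 9.47, compound 2 `COc1cccc(CNCCCNc2ccnc3cc(-c4ccc(C(F)(F)F)cc4)ccc23)c1O` gives 9.47, and compound 3 `COc1cccc(CNCCCNc2ccnc3cc(Cc4ccc(F)cc4)ccc23)c1O` gives 9.47. Compound 3 thus stands level with both others; the steps of no change at the digits printed from compound 1 to compound 2 (within the scatter), no change at the digits printed from compound 1 to compound 3 (within the scatter) and no change at the digits printed from compound 2 to compound 3 (within the scatter) all lie within the scatter. Compound 4 `COc1cccc(CNCCCNc2ccnc3cc(CC(C)C)ccc23)c1O` has not yet been measured. It differs from compound 3 by isopropyl in place of 4-fluorophenyl on a saturated chain carbon bound to an aromatic carbon. All three measured steps alter the same outer substituent without moving the readout, so the change to compound 4 is expected to leave the acid dissociation constant unchanged beyond the scatter, a step of no change at the digits printed from compound 3 to compound 4 (within the scatter). Compound 4 is therefore estimated at 9.47, within 9.2 to 9.75.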

Compound 4, acid dissociation constant: 9.47
Beside the measured number, compound 4's estimate shows no gap at the digits printed; low and high end bracket the measured number.
By their numbers in this assay, from the lowest: compounds 1, 2, 3 and 4 (each within the scatter of the next).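

In this assay, within the data shown here, compound 4 carries the first group at this place with no ring, yet isopropyl entering with 3 heavy atoms for 4-fluorophenyl with 7 gives no change at the digits printed from compound 3 to compound 4 (within the scatter). The open chain reads the same against the other two compounds, with no change at the digits printed from compound 2 to compound 4 (within the scatter) and no change at the digits printed from compound 1 to compound 4 (within the scatter). Nothing available explains this constancy. On these data alone, whether an amine, a carboxylic acid or a longer chain at this place would also leave the reading unmoved stays open. So does the effect of any change elsewhere on the shared core.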